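Series notes: methoxy in place of fluoro, compound 3 pending

The source may report more compounds than this note shows. Statements on the series, on what has been measured and on what is new or still open speak of the compounds shown alone.

Measured compounds:
compound 1 `CCOC(=O)C1=Cc2ccccc2OC1(OCc1cc(-c2ccc(OC)cc2)no1)C(F)(F)F` — > 150000 nM
compound 2 `O=C(O)C1=Cc2ccccc2OC1(OCc1cc(-c2ccc(F)cc2)no1)C(F)(F)F` — > 150000 nM

In a functional assay on HeLa cells (Homo sapiens) for inhibition, read by MTT assay, with a stated time of 24 h (on this read-out higher numbers stand for weaker inhibition and lower numbers for stronger inhibition), compound 1 gives only a limit, > 150000 nM, and no number. Compound 2 likewise gives only a limit in this assay, > 150000 nM. Both values shown sit at the same point: the limit of > 150000 nM in this assay, at which 2 of the 2 values shown sit. Among the measured compounds shown here, compound 2 therefore stands at the limit, and no measured step connects it to compound 1, so nothing in the data shows how any change moves the read-out.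

Compound 3 `COc1ccc(-c2cc(COC3(C(F)(F)F)Oc4ccccc4C=C3C(=O)O)on2)cc1` differs from compound 2 by methoxy in place of fluoro on an aromatic carbon. For the measured compounds named here, with no measured step to rest on, no step beyond the scatter is expected in this assay from compound 2 to compound 3 (a number no higher from compound 2 to compound 3 (the limit leaves the size open)). Compound 3 is accordingly expected to remain at the limit, with an estimate of 150000 nM and a range from 50000 nM to 400000 nM.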

Compound 3, half-maximal inhibitory concentration: > 150000 nM
Compound 3: a limit, no number; the forecaster's own chance of this, stated with the estimate: 80%; the middle value sits exactly at the limit.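

In this assay compound 3 gives only a limit, as do compound 1 and compound 2, so no new step can be read among the three. Left open is whether any change in this series moves the read-out at all, with every value at one point: the limit of > 150000 nM in this assay, at which 3 of the 3 values shown sit.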